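Fluoro for Chloro: Expecting Little Change in Compound 4

The source may report more compounds than this note shows. Statements on the series, on what has been measured and on what is new or still open speak of the compounds shown alone.

Of the compounds shown here, three sharing one core have been measured in a functional assay on B16-F0 cells (Mus musculus) for inhibition, read by CCK-8 assay, with a stated time of 48 h; a higher number here means a weaker inhibitor, a lower number a stronger inhibitor. Compound 1 `COc1cc(-c2ccnc3cc(-c4ccc(Cl)cc4)nn23)cc(OC)c1OC` gives 4090 nM, the second highest of the three numbers. Its nearest neighbour is compound 2 `COc1cc(-c2ccnc3cc(-c4ccccc4)nn23)cc(OC)c1OC`, which in this assay gives 4730 nM; the two differ only by hydrogen in place of chloro on an aromatic carbon, and a 1.2-fold higher number from compound 1 to compound 2 (0.06 log units; within the scatter). Compound 3 `COc1cc(-c2ccnc3cc(-c4cn(C)c5ccccc45)nn23)cc(OC)c1OC` stands far apart, giving 185 nM in this assay, reached by a 22-fold lower number from compound 1 to compound 3 (1.34 log units; beyond the scatter) and a 26-fold lower number from compound 2 to compound 3 (1.41 log units; beyond the scatter).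

Compound 4 `COc1cc(-c2ccnc3cc(-c4ccc(F)cc4)nn23)cc(OC)c1OC` has not yet been measured in this assay. It differs from compound 1 by fluoro in place of chloro on an aromatic carbon. Within the data shown here, the one step that bears directly on this exchange is the removal of chloro, a 1.2-fold higher number from compound 1 to compound 2 (0.06 log units; within the scatter), which left the number essentially where it was; the large steps to compound 3 concern a different replacement and say nothing about one halogen for another. The expected step is therefore small: a 1.1-fold higher number from compound 1 to compound 4 (0.02 log units; within the scatter), within the scatter. In this assay compound 4 is expected to give about 4300 nM, within a range from 2000 nM to 9500 nM.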

Compound 4, half-maximal inhibitory concentration: 4540 nM
Estimate against measurement, compound 4: 1.1-fold (0.02 log units) below; measured number inside the range.
By their numbers in this assay, from the lowest: compound 3; then compounds 1, 4 and 2 (each within the scatter of the next).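

Fluoro in place of chloro gives a 1.1-fold higher number from compound 1 to compound 4 (0.05 log units; within the scatter) in this assay and fluoro in place of hydrogen gives a 1.0-fold lower number from compound 2 to compound 4 (0.02 log units; within the scatter), so a second halogen now joins chloro and hydrogen, and none of the three can be told apart at this place, para to a large group. Against this flat set, 4-fluorophenyl in place of 1-methyl-1H-indol-3-yl gives a 25-fold higher number from compound 3 to compound 4 (1.39 log units; beyond the scatter), which leaves compound 3 as the only compound set clearly apart from the others. No available evidence accounts for either the flat reading or the large step.

As far as these compounds go, whether an amine, a carboxylic acid or a longer chain at this place would read equally flat remains open. So does whether a halogen exchange on the 1-methyl-1H-indol-3-yl group would make any difference.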